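Swapping Benzyloxy for Nitro on a Cytotoxicity-Silent Scaffold

This account rests on a few compounds, and the source may have more. Where it says the series, first, only, none or still open, it means among the compounds named here.

Of the compounds shown here, three have so far been tested in an ADME assay on HEK293 cells (Homo sapiens) for cytotoxicity, read by CellTiter-Glo and resazurin assay, with a stated time of 72 h; a lower number here means that less compound is needed, a higher number that more compound is needed for the effect. Compound 1 `CC(C)N(Cc1cccc(OCCCCCC(=O)O)c1)C(=O)c1ccc(-c2ccco2)cc1` gives > 26000 nM in this assay, which is a limit of the assay rather than a number. Compound 2 `CC(C)N(Cc1cccc(OCCCCCC(=O)O)c1)C(=O)c1ccc(-c2cccc(OCc3ccccc3)c2)cc1` likewise gives > 26000 nM, again only a limit. Compound 3 `CCOC(=O)CCCCCOc1cccc(CN(C(=O)c2ccc(-c3cccc(OCc4ccccc4)c3)cc2)C(C)C)c1` differs from compound 2 by ethyl in place of hydrogen on an oxygen next to a carbonyl group. In this assay compound 3 gives > 26000 nM, also a limit. Going by the values given here, the one step within this set, a step that the two limits leave unreadable from compound 2 to compound 3, therefore cannot be read in size or direction, and all that can be said of compound 3 is that it shares the limit of > 26000 nM in this assay, at which 3 of the 3 values shown sit, with the other two; nothing places it more precisely.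

Compound 4 `CCOC(=O)CCCCCOc1cccc(CN(C(=O)c2ccc(-c3cccc([N+](=O)[O-])c3)cc2)C(C)C)c1` has not yet been measured. It differs from compound 3 in one place: nitro in place of benzyloxy on an aromatic carbon. Among the compounds with values here, no measured step involves either a nitro group or a benzyloxy group, so there is no evidence to set a direction or size for this change in this assay. Within the data shown here, since every compound so far sits at the limit of > 26000 nM in this assay, at which 3 of the 3 values shown sit, compound 4 is expected to return a limit as well, with the step that the limit leaves unreadable from compound 3 to compound 4 estimated to stay within the scatter. For compound 4 the estimate in this assay is 40000 nM, between 15000 nM and 150000 nM.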

Compound 4, half-maximal effective concentration: > 26000 nM
Compound 4: a limit, no number (the forecaster's own chance of this, stated with the estimate: 80%); the middle value lies beyond the limit too.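

Compound 3 and compound 4 both return only a limit of the assay, not a number, so the step between them cannot be read in size or direction. Left open is how far beyond that limit each compound lies, and whether any change would give a readable number in this assay, for all share one result: the limit of > 26000 nM in this assay, at which 4 of the 4 values shown sit.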